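From Cyclobutylcarbonyl to Benzylcarbamoyl on a Shared Core

This account rests on a few compounds, and the source may have more. Where it says the series, first, only, none or still open, it means among the compounds named here.

Of the compounds shown here, three built on one core have been tested in a functional assay on WI-38 VA13 cells (Homo sapiens) for cytotoxicity; on this read-out higher numbers stand for an effect only at larger amounts of compound and lower numbers for an effect already at smaller amounts. Compound 1 `O=C(Nc1ccc2nc(NC(=O)C3CCCCC3)sc2c1)c1ccccc1C(F)(F)F` gives 0.024 ug/mL, compound 2 `Cc1[nH][n+](C)c(C)c1C(=O)Nc1ccc2nc(NC(=O)C3CCCCC3)sc2c1` gives 0.012 ug/mL, and compound 3 `O=C(Nc1ccc2nc(NC(=O)C3CCC3)sc2c1)c1c(Cl)cccc1Cl` gives 0.013 ug/mL. Among the compounds with values here, the only single-site step among them, a 2.0-fold lower number from compound 1 to compound 2 (0.30 log units; within the scatter), sits within the scatter. Compound 3 stands second highest of the three numbers, nearest to compound 2 and furthest from compound 1, yet both gaps lie within the scatter, so no ranking can be read from them.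

Compound 4 `O=C(NCc1ccccc1)Nc1nc2ccc(NC(=O)c3c(Cl)cccc3Cl)cc2s1` differs from compound 3 at the carbonyl carbon that carries the cyclobutyl: benzylamino in place of cyclobutyl on a carbonyl carbon. Within the data shown here, no measured step touches this position; the one step in hand altered the other amide of the core. Among the measured compounds shown here, the sole guide is that three rather different compounds all give numbers within the scatter of one another. For the measured compounds named here, the step of a 1.5-fold higher number from compound 3 to compound 4 (0.19 log units; within the scatter) is therefore expected to stay within the scatter, with a wide range since no direct precedent exists. Compound 4 is estimated at 0.02 ug/mL, between 0.005 ug/mL and 0.08 ug/mL.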

Compound 4, half-maximal effective concentration: 0.15 ug/mL
Compound 4: middle estimate off by 7.5-fold (0.88 log units), on the low side, and the stated range ends below it.
By their numbers in this assay, from the lowest: compounds 2, 3 and 1 (each within the scatter of the next); then compound 4.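

In this assay the carbonyl carbon that carries the cyclobutyl proves sensitive to change: benzylamino in place of cyclobutyl gives a 12-fold higher number from compound 3 to compound 4 (1.06 log units; beyond the scatter) and so is the only step shown that lies beyond the scatter. Within the data shown here, the three earlier compounds all lay within the scatter of one another and their one step touched the other amide, so this position had no step of its own until now, and here cyclobutylcarbonyl to benzylcarbamoyl means that a larger amount of compound is needed for the effect. No measurement available here accounts for the size of this step.

The change swaps the ring and adds a nitrogen with its hydrogen-bond donor at once, so the compounds shown cannot separate the two. A cyclobutylamino group, which has the nitrogen but keeps the cyclobutyl ring, and a phenylacetyl group, which has the benzene ring but no such nitrogen, would pull these two parts apart.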